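A few compounds are considered here, and "the series" means these few. Any claim that something is new, unique, unknown or untested is made for them only; others in the source may bear on it.

Measured so far in a functional assay on A549 cells (Homo sapiens) for cytotoxicity, read by MTT assay, with a stated time of 72 h; on this read-out higher numbers stand for weaker inhibition and lower numbers for stronger inhibition
compound 1 `O=C1c2c[n+]([O-])c3ccccc3c2C(=O)c2c1c1ccccc1n2Cc1cn([C@@H]2C[C@H](O)[C@@H](CO)O2)nn1` gives 120 nM
compound 2 `O=C1c2c[n+]([O-])c3ccccc3c2C(=O)c2c1c1ccccc1n2CCCCN1CCCCC1` gives 150 nM
compound 3 `CN1CCN(CCCn2c3c(c4ccccc42)C(=O)c2c[n+]([O-])c4ccccc4c2C3=O)CC1` gives 140 nM

The three values lie within the scatter of one another, so compound 1 at 120 nM stands level with the other two compounds and cannot be separated from them.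

Compound 4 `O=C1c2c[n+]([O-])c3ccccc3c2C(=O)c2c1c1ccccc1n2Cc1cn([C@H]2C[C@H](O)[C@@H](CO)O2)nn1` is the next compound to be read in this assay. Its change from compound 1 (the two compounds have the same atoms and bonds and differ only in configuration as drawn: 1 of 3 stereo elements differ; a stereocentre at a saturated ring carbon is drawn S in compound 1 and R in compound 4) leaves the atoms and bonds untouched: a stereocentre at a saturated ring carbon is drawn S in compound 1 and R in compound 4.

Among the measured compounds shown here, only one measured step is available, and a 1.1-fold lower number from compound 2 to compound 3 (0.03 log units; within the scatter) concerns a side chain rather than a stereocentre. It lies within the scatter. For the measured compounds named here, no measured pair tests a change of configuration, so the evidence here is indirect. Compound 2 at 150 nM and compound 3 at 140 nM stay level with compound 1 at 120 nM across different side chains, and this gives no reason to expect a large step. The estimated change, a 1.1-fold higher number from compound 1 to compound 4 (0.03 log units; within the scatter), is expected to stay within the scatter, with neither direction favoured. The expected value for compound 4 is 130 nM with an estimated range from 60 nM to 300 nM in this read-out.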

Compound 4, half-maximal inhibitory concentration: 350 nM
Compound 4: middle estimate off by 2.7-fold (0.43 log units), on the low side, outside the stated range (above it).
By their numbers in this assay, from the lowest: compounds 1, 3 and 2 (each within the scatter of the next); then compound 4.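

In this assay, among the compounds shown here, the stereocentre at the saturated ring carbon is the one place so far where a change moves the number beyond the scatter, and the S form as drawn gives the lower number, with a 2.9-fold higher number from compound 1 to compound 4 (0.46 log units; beyond the scatter) for the change to the R form. For the compounds shown here, the only earlier step, a 1.1-fold lower number from compound 2 to compound 3 (0.03 log units; within the scatter) and within the scatter, concerned a side chain, so the level values of the earlier compounds gave no reading on configuration, whereas this pair shows that the read-out responds to the arrangement at a single carbon even though no atom or bond leaves or enters. The step, modest in size, can be placed on that one stereocentre, with the other two stereo elements unchanged: the fact that compounds 1 and 4 differ only in the configuration as drawn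

Going by these compounds, the other two stereo elements remain untested, so it is open whether inverting either of them would shift the number as well or whether this carbon is a special case. Also open, on these data alone, is whether the gap between the S and R forms would persist if an amine or a carboxylic acid took the place of the hydroxymethyl group on the same saturated ring.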